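Permeability in a series of aryl-oxazole piperidine amides

The compounds below may be only part of what the source reports. "The series", "measured", "known", "first", "only" and "open" are said of these compounds alone.

The series shares one core, carried by compound 1 `Cc1oc(-c2ccc(F)cc2)nc1CN1CCC(C(=O)NCCCN2C[C@H](C)C[C@H](C)C2)CC1`, for which a physicochemical assay for permeability, using PAMPA (a higher number here means that the compound crosses the layer faster, a lower number that the compound crosses the layer more slowly), reports "not determined" (no result reported). Compound 2 `Cc1oc(-c2c(F)cccc2F)nc1CN1CCC(C(=O)NCCCN2C[C@H](C)C[C@H](C)C2)CC1` gives 82.4 10^-6 cm/s in this assay. Going by the values given here, compound 3 `Cc1cccc(F)c1-c1nc(CN2CCC(C(=O)NCCCN3C[C@H](C)C[C@H](C)C3)CC2)c(C)o1` gives 234 10^-6 cm/s, the highest of the two numbers; the nearest is compound 2, and the step of a 2.8-fold higher number from compound 2 to compound 3 (0.45 log units; beyond the scatter) was the only measured change of an aryl substituent. Compound 4 `Cc1ccc(-c2nc(CN3CCC(C(=O)NCCCN4C[C@H](C)C[C@H](C)C4)CC3)c(C)o2)c(C)c1` differs from compound 3 in one place: 2,4-dimethylphenyl in place of 2-fluoro-6-methylphenyl on an aromatic carbon. Among the compounds with values here, this change again removes a fluoro from the aryl ring and leaves two methyl groups on it, so the step from compound 2 to compound 3 is the one measured step that bears on it. That step was modest, and compound 3 already stands high, so a step of similar or smaller size upward, or none beyond the scatter, is expected: compound 4 is expected to come out at a 1.2-fold higher number from compound 3 to compound 4 (0.08 log units; within the scatter). Compound 4 is therefore estimated at 280 10^-6 cm/s, in a range from 150 10^-6 cm/s to 520 10^-6 cm/s.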

Compound 4, apparent permeability: 353 10^-6 cm/s
For compound 4 the middle estimate is 1.3-fold (0.10 log units) below the measured one, and the stated range covers the measured number.
By their numbers in this assay, from the lowest: compound 2; then compounds 3 and 4 (each within the scatter of the next).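

In this assay, replacing 2-fluoro-6-methylphenyl with 2,4-dimethylphenyl at this position on the five-membered aromatic ring gives a 1.5-fold higher number from compound 3 to compound 4 (0.18 log units; within the scatter), so the two aryl groups cannot be told apart here, although one carries a fluorine and the other only carbon. The comparison with 2,6-difluorophenyl gives a 4.3-fold higher number from compound 2 to compound 4 (0.63 log units; beyond the scatter), so compound 4, like compound 3, stands clear of compound 2, and a second aryl group with a methyl group now reads this way. Nothing shown explains these numbers.

The compounds shown leave open whether an aryl ring carrying an amine or a carboxylic acid would stay in the same range. They also leave open whether a longer chain in place of the propyl linker would change the number.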